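The source may report more compounds than this note shows. Statements on the series, on what has been measured and on what is new or still open speak of the compounds shown alone.

Working notes on the series. In a functional assay on A549 cells (Homo sapiens) for cytotoxicity, read by MTT assay, with a stated time of 72 h (on this read-out higher numbers stand for weaker inhibition and lower numbers for stronger inhibition), compound 1 (`CN(C)CCCCCn1c2c(c3ccccc31)C(=O)c1c[n+]([O-])c3ccccc3c1C2=O`) gives 210 nM and compound 2 (`CN1CCN(CCCn2c3c(c4ccccc42)C(=O)c2c[n+]([O-])c4ccccc4c2C3=O)CC1`) gives 140 nM. Going by the values given here, compound 2 has the lower of only two numbers, but the two values lie within the scatter of each other, so no order can be read from them.

The next structure is compound 3 (`O=C1c2c[n+]([O-])c3ccccc3c2C(=O)c2c1c1ccccc1n2CCN1CCCCC1`), and the change from compound 2 is piperidin-1-yl in place of (4-methylpiperazin-1-yl)methyl on a saturated chain carbon, two bonds along the chain from an aromatic nitrogen. In words, this is piperidin-1-yl in place of (4-methylpiperazin-1-yl)methyl on a saturated chain carbon, two bonds along the chain from an aromatic nitrogen. The same difference, cut further out, reads 3-(4-methylpiperazin-1-yl)propyl to 2-(piperidin-1-yl)ethyl.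

Among the compounds with values here, only one measured step bears on this, and it also alters the chain on the aromatic nitrogen: a 1.5-fold lower number from compound 1 to compound 2 (0.18 log units; within the scatter). Within the data shown here, no measured compound carries piperidin-1-yl, so the evidence is thin and the range must stay wide. On that single step, no change beyond the scatter is expected in this assay, in either direction.

The expected size is a 1.3-fold higher number from compound 2 to compound 3 (0.11 log units; within the scatter). For compound 3 the estimated value is 180 nM, with an estimated range of 60 nM to 500 nM.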

Compound 3, half-maximal inhibitory concentration: 1080 nM
Beside the measured number, compound 3's estimate is 6.0-fold (0.78 log units) below it; the measured number lies above the stated range.
By their numbers in this assay, from the lowest: compounds 2 and 1 (each within the scatter of the next); then compound 3.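

In this assay, going by these compounds alone, 2-(piperidin-1-yl)ethyl in place of 3-(4-methylpiperazin-1-yl)propyl on the shared core gives the first step beyond the scatter: a 7.7-fold higher number from compound 2 to compound 3 (0.89 log units; beyond the scatter). The step from the other measured chain points the same way, a 5.1-fold higher number from compound 1 to compound 3 (0.71 log units; beyond the scatter), while compound 1 and compound 2, whose chains also differ from each other, remain within the scatter of each other, so compound 3 stands apart from both on this read-out. Nothing at hand accounts for this rise in the number.

Chain length and the group at the end of the chain change together in both new steps, so the compounds shown do not say which of the two goes with the rise. A 3-(piperidin-1-yl)propyl chain and a 2-(4-methylpiperazin-1-yl)ethyl chain on the same core would separate the two, and a 2-(dimethylamino)ethyl chain would show whether the shorter chain behaves the same way with an open-chain amine.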